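Amide at the side-chain carbonyl of compound 2

A few compounds are considered here, and "the series" means these few. Any claim that something is new, unique, unknown or untested is made for them only; others in the source may bear on it.

For the measured compounds named here, compound 2 `CCCn1c(=O)c2nc(-c3ccc(OCC(=O)O)cc3O)[nH]c2n(CCC)c1=O` gives 37 nM in an assay on membranes from brain for antagonist activity at adenosine receptor A1 (Rattus norvegicus) (on this read-out higher numbers stand for weaker inhibition and lower numbers for stronger inhibition), the highest of the three numbers so far. Compound 1 `CCCn1c(=O)c2[nH]c(-c3ccc(OC)cc3O)nc2n(CCC)c1=O` gives 4.6 nM, a gap beyond the scatter. Compound 3 `CCCn1c(=O)c2nc(-c3ccc(OCC(=O)OCC)cc3O)[nH]c2n(CCC)c1=O` gives 31 nM, and the step of a 1.2-fold lower number from compound 2 to compound 3 (0.08 log units; within the scatter) lies within the scatter.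

Compound 4 `CCCn1c(=O)c2nc(-c3ccc(OCC(=O)NCCN(C)C)cc3O)[nH]c2n(CCC)c1=O` has not been measured. Relative to compound 2 the change is (2-(dimethylamino)ethyl)amino in place of hydroxy on a carbonyl carbon. Going by the values given here, the one measured step at this carbonyl, the one from compound 2 to compound 3, altered the number by no more than the scatter, so changes at this carbonyl have so far left the read-out essentially unmoved; no measured step covers an amide here.

On that basis the step of a 1.2-fold lower number from compound 2 to compound 4 (0.09 log units; within the scatter) is expected to stay within the scatter. Among the compounds with values here, compound 4 is therefore estimated at 30 nM, with a range from 10 nM to 90 nM in this assay, the range kept wide because the only related step, a 1.2-fold lower number from compound 2 to compound 3 (0.08 log units; within the scatter), is a single observation.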

Compound 4, antagonist equilibrium constant: 8.4 nM
The estimate for compound 4 lay 3.6-fold (0.55 log units) above the measured number, and the stated range ends above it.
By their numbers in this assay, from the lowest: compounds 1 and 4 (each within the scatter of the next); then compounds 3 and 2 (each within the scatter of the next).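

In this assay, the carbonyl carbon of the carboxymethoxy side chain no longer appears indifferent to its substituent: (2-(dimethylamino)ethyl)amino in place of hydroxy gives a 4.4-fold lower number from compound 2 to compound 4 (0.64 log units; beyond the scatter) and in place of ethoxy gives a 3.7-fold lower number from compound 3 to compound 4 (0.57 log units; beyond the scatter). Both steps lie beyond the scatter, whereas a 1.2-fold lower number from compound 2 to compound 3 (0.08 log units; within the scatter) does not, so this position responds to the change to the amide with its dimethylamino end, though not to ethyl on the acid oxygen. The data on hand offer no explanation for this difference.

The compounds shown do not separate the contribution of the amide link from that of the terminal dimethylamino group. A simple carbamoyl, a (2-hydroxyethyl)amino group and the longer (3-(dimethylamino)propyl)amino chain at this carbonyl would each address that question.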